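Metabolic stability of sulfonyl variants on the shared core

The compounds below may be only part of what the source reports. "The series", "measured", "known", "first", "only" and "open" are said of these compounds alone.

Measured so far in an ADME assay on microsomes from liver (Homo sapiens) for metabolic stability, with a stated time of 10 min; a lower number here means that less of the compound is left, a higher number that more of the compound is left:
compound 1 `Cc1ccccc1S(=O)(=O)NC(=O)c1ccc(Nc2nc(NC3(c4ccc(Cl)cc4)CC3)nc(OCC(F)(F)F)n2)cc1`, 100%
compound 2 `CC(C)(C)NC(=O)NCCS(=O)(=O)NC(=O)c1ccc(Nc2nc(NC3(c4ccc(Cl)cc4)CC3)nc(OCC(F)(F)F)n2)cc1`, 96%
compound 3 `CCCCCNc1nc(Nc2ccc([N+](=O)[O-])cc2)nc(OCC(F)(F)F)n1`, 74%

Compound 2 sits within the scatter of compound 1 and clearly beyond it against compound 3, whose value is markedly lower. Going by the values given here, the one step measured on the sulfonyl sulfur, a number 4 percentage points lower from compound 1 to compound 2 (within the scatter), shows that exchanging the group on that sulfur left the result unchanged within the scatter.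

Compound 4 `CC(C)S(=O)(=O)NC(=O)c1ccc(Nc2nc(NC3(c4ccc(Cl)cc4)CC3)nc(OCC(F)(F)F)n2)cc1` is the next variant: isopropyl in place of 2-(((tert-butyl)carbamoyl)amino)ethyl on a sulfonyl sulfur. The step from compound 1 to compound 2 is the only one that bears on this change, and it was within the scatter, so no step beyond the scatter is expected here either. Compound 3 carries a different substitution pattern on the core and is not a close comparator for this sulfonyl exchange.

For compound 4 the expected result in this assay is 95%, with a range of 80% to 100%, which means an expected step of a number 1 percentage points lower from compound 2 to compound 4 (within the scatter).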

Compound 4, percent of the compound remaining: 100%
Estimate against measurement, compound 4: 5 percentage points below; the range from low to high includes it.
By their numbers in this assay, from the lowest: compound 3; then compounds 2, 1 and 4 (each within the scatter of the next).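

The sulfonyl sulfur now carries three groups with no step beyond the scatter among those read: isopropyl in place of 2-(((tert-butyl)carbamoyl)amino)ethyl gives a number 4 percentage points higher from compound 2 to compound 4 (within the scatter) and isopropyl in place of 2-methylphenyl gives no change at the digits printed from compound 1 to compound 4 (within the scatter) in this assay. Unlike the earlier single step, this covers a group with 3 heavy atoms, no ring and no hydrogen-bond donors or acceptors as well as a chain with 10 heavy atoms, 2 donors and 1 acceptor, so on this core the read-out has not separated the groups at this position. No supporting data bear on why the result stays within the scatter.

On these data alone, whether a primary amine, a carboxylic acid or a longer alkyl chain on the same sulfur would also stay within the scatter remains open. So does whether the isopropyl exchange would behave alike on the core of compound 3.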